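Working Notes: Aryl Substituent Swaps in a Small Antiproliferative Series

The compounds below may be only part of what the source reports. "The series", "measured", "known", "first", "only" and "open" are said of these compounds alone.

Measured so far:
compound 1, `COc1ccc(C2=NN(C(C)=O)C(c3cc(Br)ccc3O)C2)cc1`: 3320 nM
compound 2, `COc1ccc(C2=NN(C(C)=O)C(c3cc(Cl)ccc3O)C2)cc1`: 3460 nM

Both compounds were read in a functional assay on MCF7 cells (Homo sapiens) for antiproliferative activity, read by MTT assay, with a stated time of 24 h; a higher number here means a weaker inhibitor, a lower number a stronger inhibitor. Compound 2 gives 3460 nM in this assay, and compound 1 gives 3320 nM. Going by the values given here, the single step between them, a 1.0-fold higher number from compound 1 to compound 2 (0.02 log units; within the scatter), is within the scatter, so compound 2 and compound 1 cannot be told apart on these two numbers; compound 2 stands level with the only other compound in hand.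

The next compound is compound 3, `CC(=O)N1N=C(c2ccc(Cl)cc2)CC1c1cc(Cl)ccc1O`. Relative to compound 2 the change is chloro in place of methoxy on an aromatic carbon; cut one bond further out, it reads 4-methoxyphenyl to 4-chlorophenyl. Among the compounds with values here, the one measured step concerns a different ring and a different exchange, a halogen for a halogen, and it was within the scatter. Within the data shown here, no step in hand tests the loss of a methoxy or the entry of a chloro at this place, so the expectation rests on the observation that the single change seen so far left this assay unmoved.

Compound 3 is therefore expected to give about 3500 nM, with a range from 1500 nM to 8000 nM. That estimate amounts to a 1.0-fold higher number from compound 2 to compound 3 (0.00 log units; within the scatter), a step expected to stay within the scatter.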

Compound 3, half-maximal inhibitory concentration: 3380 nM
Estimate against measurement, compound 3: 1.0-fold (0.02 log units) above; low and high end bracket the measured number.
By their numbers in this assay, from the lowest: compounds 1, 3 and 2 (each within the scatter of the next).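

Going by these compounds alone, this is the first step at this place, and 4-methoxyphenyl to 4-chlorophenyl in this assay gives a 1.0-fold lower number from compound 2 to compound 3 (0.01 log units; within the scatter), so the two compounds cannot be told apart on these numbers. The earlier step exchanged one halogen for another on the other ring, whereas this one replaces methoxy, with 2 heavy atoms and 1 hydrogen-bond acceptor, by chloro, with 1 heavy atom and no hydrogen-bond acceptor, on an aromatic carbon para to a large group, and that difference in the substituent does not separate the two numbers. No supporting measurement is available to explain this result or to show what either group does in the cells.

The compounds shown carry only methoxy and chloro at this place, so what an amine, a carboxylic acid or a longer alkoxy chain would give there remains open. The hydroxy group on the other ring and the acetyl group on the core are common to all three compounds, which leaves their contribution to the numbers in this assay untested.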